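Bromo for Isopropyl: Expected Effect on Inhibition

The source may report more compounds than this note shows. Statements on the series, on what has been measured and on what is new or still open speak of the compounds shown alone.

Compound 1 `C=C1C(=O)OC[C@H]1CCOC(=O)Nc1ccc(C(C)C)cc1` is the strongest of the three compounds measured in a functional assay on RAW264.7 cells (Mus musculus) for inhibition, with a stated time of 30 min (a higher number here means a weaker inhibitor, a lower number a stronger inhibitor), where compound 1 gives 340 nM. Its stereoisomer, compound 2 `C=C1C(=O)OC[C@@H]1CCOC(=O)Nc1ccc(C(C)C)cc1`, gives 1580 nM, and a 4.6-fold higher number from compound 1 to compound 2 (0.67 log units; beyond the scatter); the only difference between them is the fact that compounds 1 and 2 differ only in the configuration as drawn. Compound 3 `C=C1C(=O)OC[C@H]1CCOC(=O)Nc1ccc(C)c(C)c1`, which carries two methyl groups on the aromatic ring instead of the isopropyl, gives 1090 nM, a weaker result than compound 1.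

Compound 4 `C=C1C(=O)OC[C@H]1CCOC(=O)Nc1ccc(Br)cc1` has not yet been measured. Compared with compound 1, the change is bromo in place of isopropyl on an aromatic carbon. Going by the values given here, none of the measured steps touches this part of the molecule: the single step available, from compound 1 to compound 2, alters only the stereocentre and leaves the aromatic substituent untouched, so it offers no guide to the size or direction of the present change. Among the compounds with values here, with no direct precedent, the expectation is a step of a 1.5-fold higher number from compound 1 to compound 4 (0.17 log units; within the scatter), a shift that stays within the usual scatter of this assay. Compound 4 is therefore estimated to give 500 nM in this assay, with a range from 170 nM to 1500 nM.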

Compound 4, half-maximal inhibitory concentration: 350 nM
Estimate against measurement, compound 4: 1.4-fold (0.15 log units) above; low and high end bracket the measured number.
By their numbers in this assay, from the lowest: compounds 1 and 4 (each within the scatter of the next); then compounds 3 and 2 (each within the scatter of the next).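

Going by these compounds alone, putting bromo in place of isopropyl gives a 1.0-fold higher number from compound 1 to compound 4 (0.01 log units; within the scatter) in this assay, which is the first direct reading of what this place on the aromatic ring allows. Here, 3 heavy atoms, all carbon, are exchanged for 1 bromine atom, yet compound 1 and compound 4 cannot be told apart in this assay, so for this pair the number of heavy atoms at this spot does not separate the two inhibitors. Nothing in the information at hand explains why these two groups give such closely matching numbers.

Two groups that read alike say little about the wider range of groups this position might accept, so an amine, a carboxylic acid, a methoxy group or a longer chain on the same aromatic carbon could give a quite different number. On these data alone, it also remains open whether bromo would match isopropyl on the opposite stereoisomer, the configuration drawn in compound 2, or whether the match holds only for the configuration shared by compound 1 and compound 4.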